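Swapping the aryl group on the hydrazone of a shared core

A few compounds are considered here, and "the series" means these few. Any claim that something is new, unique, unknown or untested is made for them only; others in the source may bear on it.

Measured compounds:
Compound 1 `CCCSc1nc(N/N=C/c2ccccc2Cl)c2nnn(Cc3ccccc3)c2n1` gives 10900 nM in a functional assay on MGC-803 cells (Homo sapiens) for antiproliferative activity, read by MTT assay, with a stated time of 72 h; on this read-out lower numbers stand for stronger inhibition and higher numbers for weaker inhibition.
Compound 3 `CCCSc1nc(N/N=C/c2c(O)ccc3ccccc23)c2nnn(Cc3ccccc3)c2n1` gives 3710 nM in this assay.
Compound 2 `CCCSc1nc(N/N=C/c2ccc(Cl)cc2)c2nnn(Cc3ccccc3)c2n1` gives only a limit of the assay, > 64000 nM, in this assay.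

Compound 3 has the lowest number of the two actual values; the step from compound 1 to compound 3 was a 2.9-fold lower number from compound 1 to compound 3 (0.47 log units; beyond the scatter), and from compound 2 to compound 3 an at least 17-fold lower number from compound 2 to compound 3 (1.23 log units; beyond the scatter). Compound 4 `CCCSc1nc(N/N=C/c2ccc3ccccc3c2)c2nnn(Cc3ccccc3)c2n1` differs by naphthalen-2-yl in place of 2-hydroxynaphthalen-1-yl on a carbon with a double bond to nitrogen. All three measured steps change this same aryl group, and each favours compound 3, though none removes the hydroxyl or shifts the attachment on naphthalene. A modestly higher number is therefore expected for compound 4, a 2.4-fold higher number from compound 3 to compound 4 (0.38 log units; beyond the scatter), estimated at 9000 nM (range 2500 nM to 35000 nM).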

Compound 4, half-maximal inhibitory concentration: > 64000 nM
Compound 4: a limit, no number; the forecaster's own chance of this, stated with the estimate: 10%; middle value at least 7.1-fold (0.85 log units) from the limit.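

Compound 4 keeps both six-membered aromatic rings of carbon, yet this assay shows an at least 17-fold higher number from compound 3 to compound 4 (1.23 log units; beyond the scatter), so on this carbon with a double bond to nitrogen those rings alone are not enough. The same group also compares poorly with 2-chlorophenyl, with an at least 5.8-fold higher number from compound 1 to compound 4 (0.76 log units; beyond the scatter). Compound 2 and compound 4 each give only a limit, so the step between them cannot be read: the limit of > 64000 nM in this assay, at which 2 of the 4 values shown sit.

This change removes the hydroxyl and shifts the attachment together, and the compounds shown do not separate the two. On these data alone, whether a methoxy group in place of the hydroxyl would keep the lower number stays open.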